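The compounds below may be only part of what the source reports. "The series", "measured", "known", "first", "only" and "open" are said of these compounds alone.

Compound 1 `O=C(NCCCCc1ccccc1)n1c(=O)oc2cc(-c3ccc(F)cc3)ccc21`: in an assay on HEK293 cells for inhibition of acid ceramidase (Homo sapiens), with a stated time of 10 min (a higher number here means a weaker inhibitor, a lower number a stronger inhibitor), compound 1 gives 79 nM.
Compound 2 `COc1ccc(-c2ccc3c(c2)oc(=O)n3C(=O)NCCCCc2ccccc2)cc1`: compound 2 gives 67 nM.
Compound 3 `O=C(NCCCCc1ccccc1)n1c(=O)oc2cc([N+](=O)[O-])ccc21`: compound 3 gives 3 nM.

Compound 3 stands lowest of the three, with the large steps of a 26-fold lower number from compound 1 to compound 3 (1.42 log units; beyond the scatter) and a 22-fold lower number from compound 2 to compound 3 (1.35 log units; beyond the scatter), whereas a 1.2-fold lower number from compound 1 to compound 2 (0.07 log units; within the scatter) is within the scatter. Compound 4 `O=C(NCCCCc1ccccc1)n1c(=O)oc2cc(Cl)ccc21` differs from compound 3 in one place: chloro in place of nitro on an aromatic carbon. Among the measured compounds shown here, no measured step exchanges nitro for chloro; the two steps that bear on it only show that nitro at this position gives a far lower number than either aryl group. Chloro is untested, so compound 4 is expected to lose part of that gain and give a higher number, with an estimated step of an 8.3-fold higher number from compound 3 to compound 4 (0.92 log units; beyond the scatter). Compound 4 is estimated at 25 nM, between 7 nM and 90 nM.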

Compound 4, half-maximal inhibitory concentration: 33 nM
For compound 4 the middle estimate is 1.3-fold (0.12 log units) below the measured one; the measured number falls inside the stated range.
By their numbers in this assay, from the lowest: compound 3; then compound 4; then compounds 2 and 1 (each within the scatter of the next).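

In this assay, chloro lands on neither side: an 11-fold higher number from compound 3 to compound 4 (1.04 log units; beyond the scatter) is a large step away from nitro, while a 2.0-fold lower number from compound 2 to compound 4 (0.31 log units; beyond the scatter) and a 2.4-fold lower number from compound 1 to compound 4 (0.38 log units; beyond the scatter) are modest steps away from the two aryl groups. Removing the aryl ring alone therefore does not reach the low number of compound 3, as chloro, also without a ring, recovers only part of that gain. Nothing shown gives a cause for this order. As far as these compounds go, whether a nitrile or an amine at this position would match nitro remains open, as does whether nitro keeps its lead elsewhere on the shared core.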